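Aryl ester swap on the shared core

This account rests on a few compounds, and the source may have more. Where it says the series, first, only, none or still open, it means among the compounds named here.

Values in a functional assay on CaEs17 cells (Homo sapiens) for cytotoxicity, read by MTT assay, with a stated time of 72 h; a higher number here means a weaker inhibitor, a lower number a stronger inhibitor:
- compound 1 `C=C1C(=O)[C@@]23C(=O)OC[C@]4(C(=O)CCC(C)(C)[C@H]4C=O)[C@@H]2CC[C@@H]1[C@H]3O`: 5850 nM
- compound 2 `C=C1C(=O)[C@@]23C(=O)OC[C@]4(C(=O)CCC(C)(C)[C@H]4C=O)[C@@H]2CC[C@@H]1[C@H]3OC(=O)c1ccc(C(F)(F)F)cc1`: 8960 nM
- compound 3 `C=C1C(=O)[C@@]23C(=O)OC[C@]4(C(=O)CCC(C)(C)[C@H]4C=O)[C@@H]2CC[C@@H]1[C@H]3OC(=O)c1ccc(F)cc1`: 8310 nM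

Compound 3 lies within the scatter of both other compounds, so the three values cannot be ranked. Next is compound 4 `C=C1C(=O)[C@@]23C(=O)OC[C@]4(C(=O)CCC(C)(C)[C@H]4C=O)[C@@H]2CC[C@@H]1[C@H]3OC(=O)c1ccccc1Cl`, with 2-chlorophenyl in place of 4-fluorophenyl on a carbonyl carbon. Among the measured compounds shown here, no measured compound carries this group. The nearest evidence is a 1.5-fold higher number from compound 1 to compound 2 (0.19 log units; within the scatter), a 1.4-fold higher number from compound 1 to compound 3 (0.15 log units; within the scatter) and a 1.1-fold lower number from compound 2 to compound 3 (0.03 log units; within the scatter). None of these leaves the scatter, so no shift beyond it is expected in this assay. The expected step is a 1.0-fold lower number from compound 3 to compound 4 (0.02 log units; within the scatter). Compound 4 is estimated at 8000 nM, with an expected range of 4500 nM to 14000 nM.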

Compound 4, half-maximal inhibitory concentration: 2010 nM
Compound 4: the middle estimate sits 4.0-fold (0.60 log units) above what was measured; measured number outside the range, below it.
By their numbers in this assay, from the lowest: compound 4; then compounds 1, 3 and 2 (each within the scatter of the next).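

In this assay, the aryl group on this carbonyl carbon now matters: a 4.1-fold lower number from compound 3 to compound 4 (0.62 log units; beyond the scatter) and a 4.5-fold lower number from compound 2 to compound 4 (0.65 log units; beyond the scatter), both beyond the scatter. Compound 4 also separates from the free alcohol, with a 2.9-fold lower number from compound 1 to compound 4 (0.46 log units; beyond the scatter), whereas compound 2 and compound 3 stayed within the scatter of compound 1. Nothing available explains these steps.

As far as these compounds go, whether the chlorine or its place on the ring carries the step stays open. So does how an amine or a carboxylic acid on that phenyl ring, or an alkyl chain in its stead, would read.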